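The compounds below may be only part of what the source reports. "The series", "measured", "known", "first", "only" and "open" are said of these compounds alone.

Compound 1 `Cc1ccc([N+](=O)[O-])cc1S(=O)(=O)N[C@H]1CCN(Cc2cnn3ccc(C#N)cc23)C1` and compound 2 `Cc1ccc([N+](=O)[O-])cc1C(=O)N[C@H]1CCN(Cc2cnn3ccc(C#N)cc23)C1` share a core and differ only in the linker to the nitro-bearing ring. In an assay on isolated protein for inhibition of phosphatidylinositol 4,5-bisphosphate 3-kinase catalytic subunit beta isoform (Homo sapiens) (on this read-out higher numbers stand for weaker inhibition and lower numbers for stronger inhibition), compound 1 gives only a limit, > 1000 nM. In this assay compound 2 likewise gives only a limit, > 1000 nM, so its standing is known solely as a ceiling, as both values sit at the limit (the limit of > 1000 nM in this assay, at which 2 of the 2 values shown sit). Compound 3 `Cc1ccc([N+](=O)[O-])cc1C(=O)N[C@@H]1CCN(Cc2cnn3ccc(C#N)cc23)C1` is its mirror partner: the two compounds have the same atoms and bonds and differ only in configuration as drawn: 1 of 1 stereo elements differ; a stereocentre at a saturated ring carbon is drawn S in compound 2 and R in compound 3. For the measured compounds named here, with no measured step to go on, compound 3 is expected to change by an at least 1.6-fold lower number from compound 2 to compound 3 (0.22 log units; that floor lies within the scatter), arriving at an estimated 600 nM, between 60 nM and 5000 nM.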

Compound 3, half-maximal inhibitory concentration: > 1000 nM
Compound 3 was reported as a limit; the forecaster's own chance of this, stated with the estimate: 45%; middle value at least 1.6-fold (0.22 log units) away from the limit.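

Compound 3 gives only a limit in this assay, as compound 2 does, so no step between compound 2 and compound 3 can be read: the limit of > 1000 nM in this assay, at which 3 of the 3 values shown sit.

The compounds shown leave open how strongly any of them inhibits, and whether configuration changes inhibition at all.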